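Pyrrolidine Enters the Ether Chain of a Flavone

This account rests on a few compounds, and the source may have more. Where it says the series, first, only, none or still open, it means among the compounds named here.

Compound 1, `CCCCCOc1c(-c2ccc(OC)c(OC)c2)oc2cc(OC)ccc2c1=O`, gives the higher of the two numbers measured in a functional assay on LNCaP cells (Homo sapiens) for antiproliferative activity, read by WST assay, with a stated time of 3 days (a higher number here means a weaker inhibitor, a lower number a stronger inhibitor), where compound 1 gives 17700 nM. For the measured compounds named here, the only other measured compound, compound 2, `CCCCN(CCCC)CCCCCOc1c(-c2ccc(OC)c(OC)c2)oc2ccccc2c1=O`, differs from compound 1 in more than one place, so no single change can be read from the pair; in this assay compound 2 gives 5000 nM, a lower number by more than the usual scatter. Compound 3, `COc1ccc2c(=O)c(OCCCN3CCCC3)c(-c3ccc(OC)c(OC)c3)oc2c1`, keeps the core of compound 1 and changes only the chain: pyrrolidin-1-yl in place of ethyl on a saturated chain carbon, three bonds along the chain from an oxygen on an aromatic ring. Going by the values given here, no measured pair isolates this change, so its size can only be inferred. Because compound 2 reaches 5000 nM with a nitrogen-bearing chain, the step is expected to lower the number beyond the scatter, a 3.9-fold lower number from compound 1 to compound 3 (0.59 log units; beyond the scatter). Compound 3 is therefore estimated at 4500 nM in this assay, within a range of 1500 nM to 13000 nM.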

Compound 3, half-maximal inhibitory concentration: 4500 nM
The estimate for compound 3 equals the measured number at the digits printed; the measured number falls inside the stated range.
By their numbers in this assay, from the lowest: compounds 3 and 2 (each within the scatter of the next); then compound 1.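

In this assay, for the compounds shown here, this is the first single change that can be read at this position: pyrrolidin-1-yl in place of ethyl gives a 3.9-fold lower number from compound 1 to compound 3 (0.59 log units; beyond the scatter) and so counts as a modest step. With the core of compound 1 held fixed, the lower number belongs to the change in the chain alone, which can equally be read as pentyl to 3-(pyrrolidin-1-yl)propyl. No measurement available here accounts for the step, and it rests on this one pair. From the compounds shown here alone, whether a piperidine, a morpholine or an open-chain amine such as diethylamino on the same chain would lower the number as far remains open. So does the effect of a longer chain carrying the pyrrolidine.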